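The source may report more compounds than this note shows. Statements on the series, on what has been measured and on what is new or still open speak of the compounds shown alone.

Compound 3 (`Cc1ccc(-c2c(CNC(C)(C)C)c(C(=O)O)nn2-c2ccc(Cl)cc2)cc1`) reads > 629000 nM in a functional assay on MCF7 cells (Homo sapiens) for inhibition, read by sulforhodamine B assay, with a stated time of 48 h (on this read-out lower numbers stand for stronger inhibition of growth and higher numbers for weaker inhibition of growth), and this reading is a limit and not a number. Compound 1 (`CC(C)(C)NCc1c(C(=O)O)nn(-c2ccc(Cl)cc2)c1-c1ccc(Cl)cc1`) gives 246000 nM in this assay and compound 2 (`CC(C)(C)NCc1c(C(=O)O)nn(-c2ccc(Cl)cc2)c1-c1ccc(Br)cc1`) gives 221000 nM there. Chloro and bromo are not separated, with a 1.1-fold lower number from compound 1 to compound 2 (0.05 log units; within the scatter) on that exchange.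

The next change is nitro in place of methyl on an aromatic carbon and leads to compound 4 (`CC(C)(C)NCc1c(C(=O)O)nn(-c2ccc(Cl)cc2)c1-c1ccc([N+](=O)[O-])cc1`), with nitro in place of methyl on an aromatic carbon, that is, 4-methylphenyl to 4-nitrophenyl. For the measured compounds named here, no measured compound carries nitro, so the only guides are the two steps into methyl at this place. These are an at least 2.5-fold higher number from compound 1 to compound 3 (0.40 log units; beyond the scatter) and an at least 2.8-fold higher number from compound 2 to compound 3 (0.45 log units; beyond the scatter) and they point the same way among these three compounds. Taking methyl away is therefore expected to lower the number toward the level of the halogen compounds, although the size is uncertain and compound 4 may also return only a limit. The expected step is an at least 2.0-fold lower number from compound 3 to compound 4 (0.32 log units; beyond the scatter) in this estimate. For compound 4 the estimated value is 300000 nM with an expected range from 130000 nM to 650000 nM in this growth read-out.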

Compound 4, concentration for 50% growth inhibition: 550000 nM
Compound 4: the middle estimate sits 1.8-fold (0.26 log units) below what was measured; low and high end bracket the measured number.
By their numbers in this assay, from the lowest: compounds 2 and 1 (each within the scatter of the next); then compound 4. At a limit, above all of these: compound 3.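

Nitro is the first group at this place, para to a large group, that gives a measured number clearly separated from the halogen pair in this assay: a 2.5-fold higher number from compound 2 to compound 4 (0.40 log units; beyond the scatter) and a 2.2-fold higher number from compound 1 to compound 4 (0.35 log units; beyond the scatter). Both non-halogen groups therefore sit on the weaker side of compounds 1 and 2 among these four compounds, with none going against this, while the step from methyl to nitro gives only a floor that does not order them, an at least 1.1-fold lower number from compound 3 to compound 4 (0.05 log units; that floor lies within the scatter). The reading for compound 3 is a limit and not a number: the limit of > 629000 nM in this assay, at which 1 of the 4 values shown sits.

Open, going by these compounds, is whether any other group at this place, such as an amine, a methoxy group or a carboxylic acid, would give a number below those of the halogen pair, and whether fluoro or iodo would stay level with chloro and bromo. Also open, on these data alone, is whether this order among chloro, bromo, methyl and nitro would hold with a different amine in place of the tert-butylamino group or an ester or amide in place of the carboxylic acid on the shared core.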